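A few compounds are considered here, and "the series" means these few. Any claim that something is new, unique, unknown or untested is made for them only; others in the source may bear on it.

Two compounds of this series have a number in an ADME assay on the whole organism (Macaca fascicularis) for metabolic stability, read by LC-MS, using cassette dosing, at a dose of 1 mg/kg by the oral route; a lower number here means that the compound disappears faster, a higher number that the compound lasts longer. Compound 1 `CCCCN(c1nc2c(CO)cccc2o1)[C@H](C)c1ccc(-c2ccccc2-c2nnn[nH]2)cc1` gives 1.6 h. Compound 2 `Cc1ccc(-c2nc(=O)o[nH]2)c(-c2ccc([C@@H](C)N(CC3CC3)c3nc4c(C(=O)O)cccc4o3)cc2)c1` gives 2.8 h. Compound 1 holds the lower of the two readings, but its gap to compound 2 falls within the usual scatter, so the two cannot be placed in order with any confidence. Compound 3 `CCCCN(c1nc2c(C(=O)NC)cccc2o1)[C@H](C)c1ccc(-c2ccccc2-c2nnn[nH]2)cc1` has not yet been run in this assay. It differs from compound 1 in one place: methylcarbamoyl in place of hydroxymethyl on an aromatic carbon. Among the measured compounds shown here, no pair of measured compounds that differ in a single place is present, so no measured step can guide the outlook, and the two numbers in hand sit within the scatter of each other. The expected step is a 1.3-fold higher number from compound 1 to compound 3 (0.10 log units; within the scatter), which is none beyond the scatter. For compound 3 in this assay the estimate is 2 h, with a range from 1 h to 4 h.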

Compound 3, half-life: 1.3 h
The estimate for compound 3 lay 1.5-fold (0.19 log units) above the measured number, and the stated range covers the measured number.
By their numbers in this assay, from the lowest: compounds 3, 1 and 2 (each within the scatter of the next, the first and the last beyond it).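

Among the compounds shown here, this is the first pair that differs in one place, and it bears directly on the aromatic carbon ortho to a fused ring. In this assay, methylcarbamoyl in place of hydroxymethyl gives a 1.2-fold lower number from compound 1 to compound 3 (0.09 log units; within the scatter), so at this position the two groups cannot be told apart, even though methylcarbamoyl brings more heavy atoms and a double bond outside the aromatic rings. No measurement in hand offers a reason for this reading.

From the compounds shown here alone, whether a nitrile, an aminomethyl group or dimethylcarbamoyl on this aromatic carbon would shift the half-life beyond the scatter remains open. Also open, going by these compounds, is whether the exchange of hydroxymethyl for methylcarbamoyl would read the same on a core other than that of compound 1.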